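This account rests on a few compounds, and the source may have more. Where it says the series, first, only, none or still open, it means among the compounds named here.

Three compounds share a core and were tested in a functional assay on the whole organism (artery, strain albino) with Rattus norvegicus as the target, with a stated time of 60 min, at a dose of 10 mg/kg by the oral route; on this read-out lower numbers stand for less inhibition and higher numbers for more inhibition at the one dose given (going by the name of the read-out). Compound 1 `CC1=C(C(=O)Nc2ccc(F)cc2)C(c2ccc([N+](=O)[O-])cc2)N=C(SCc2cccc(Cl)c2)N1` gives 7.2% there. Compound 2 `CC1=C(C(=O)Nc2ccc(F)cc2)C(c2ccc([N+](=O)[O-])cc2)N=C(SCc2ccc(Cl)cc2)N1` differs from compound 1 in one place, (4-chlorophenyl in place of 3-chlorophenyl on a saturated chain carbon bound to a sulfur), and compound 2 gives 11.8%. The step recorded is a number 4.6 percentage points higher from compound 1 to compound 2 (within the scatter), so no real change can be claimed from it. Compound 3 `CC1=C(C(=O)Nc2ccc(Br)cc2)C(c2ccc(Cl)cc2Cl)N=C(SCc2cccc(Cl)c2)N1` gives 6.2% in this assay; how its core differs from that of compound 1 is not broken down here, and its value and those of compound 1 and compound 2 all sit within the scatter of one another.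

Compound 4 `CC1=C(C(=O)Nc2ccc(Br)cc2)C(c2ccc(Cl)cc2Cl)N=C(SCc2ccc(Cl)cc2)N1` is not yet measured. It stands to compound 3 as compound 2 stands to compound 1, with the same change in the same place, (4-chlorophenyl in place of 3-chlorophenyl on a saturated chain carbon bound to a sulfur). Because the earlier step was a number 4.6 percentage points higher from compound 1 to compound 2 (within the scatter), the step from compound 3 to compound 4 is expected to be small as well, estimated as a number 2.8 percentage points higher from compound 3 to compound 4 (within the scatter). On that basis compound 4 is expected to give about 9% in this assay, estimated to fall between 0% and 20%.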

Compound 4, a percentage reported as inhibition, in the whole organism at one dose (the size of the read-out at that dose, not a potency): 11.8%
The estimate for compound 4 lay 2.8 percentage points below the measured number; measured number inside the range.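

Placing 4-chlorophenyl in place of 3-chlorophenyl on a saturated chain carbon bound to a sulfur gives, in this assay, a number 5.6 percentage points higher from compound 3 to compound 4 (within the scatter). Set beside the earlier step, the same change gives matching results on the two cores: the same change on two cores in this assay, a number 4.6 percentage points higher (within the scatter) from compound 1 to compound 2 and a number 5.6 percentage points higher (within the scatter) from compound 3 to compound 4, 1 percentage points apart, within the scatter of two such steps. This shows only that nothing in these two pairs separates one core from the other; with both steps inside the scatter, it does not show that the change has a real effect on either core, so there is no firm effect to carry across, and a single oral dose says nothing about potency.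

Every compound shown carries either 3-chlorobenzyl or 4-chlorobenzyl on the sulfur, so it remains open whether a plain ethyl chain, or a chain ending in an amine or a carboxylic acid, would give a step beyond the scatter. The two cores also differ in more than one place, so the compounds shown cannot say what each of those differences does alone.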